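Methoxy for Dimethylamino on the Side Ring: Expected Bioavailability

This account rests on a few compounds, and the source may have more. Where it says the series, first, only, none or still open, it means among the compounds named here.

Of the compounds shown here, three sharing one core have been measured in an ADME assay on the whole organism for pharmacokinetics, with Rattus norvegicus as the target, at a dose of 10 mg/kg by the oral route; on this read-out lower numbers stand for lower oral bioavailability and higher numbers for higher oral bioavailability. Compound 1 `COc1cc2nnc(C(N)=O)c(Nc3ccc(C)cc3F)c2cc1N1CCN(C)CC1` gives 100%, compound 2 `COc1cc2nnc(C(N)=O)c(Nc3ccc(C)cc3F)c2cc1N1C[C@@H](C)N[C@@H](C)C1` gives 61%, and compound 3 `COc1cc2nnc(C(N)=O)c(Nc3ccc(C)cc3F)c2cc1N1CCC(N(C)C)CC1` gives 15%, the lowest of the three, reached by a number 85 percentage points lower from compound 1 to compound 3 (beyond the scatter) and by a number 46 percentage points lower from compound 2 to compound 3 (beyond the scatter). Compound 4 `COc1cc2nnc(C(N)=O)c(Nc3ccc(C)cc3F)c2cc1N1CCC(OC)CC1` differs from compound 3 by methoxy in place of dimethylamino on a saturated ring carbon. Among the measured compounds shown here, none of the measured steps swaps these two groups, so there is no direct precedent; the measured steps only show that changing the side ring on the core can shift this read-out by large amounts, as seen in a number 39 percentage points lower from compound 1 to compound 2 (beyond the scatter). A moderate rise is therefore expected rather than known, and for compound 4 the estimate is 40%, within 10% to 80%, an expected step of a number 25 percentage points higher from compound 3 to compound 4 (beyond the scatter).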

Compound 4, oral bioavailability: 21%
Compound 4: the middle estimate sits 19 percentage points above what was measured; measured number inside the range.
By their numbers in this assay, from the lowest: compounds 3 and 4 (each within the scatter of the next); then compound 2; then compound 1.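

In this assay, methoxy in place of dimethylamino on this saturated ring carbon gives a step within the scatter (a number 6 percentage points higher from compound 3 to compound 4 (within the scatter)), so the two groups cannot be told apart here. The 4-methoxypiperidin-1-yl compound also stays well short of both piperazine compounds (a number 40 percentage points lower from compound 2 to compound 4 (beyond the scatter); a number 79 percentage points lower from compound 1 to compound 4 (beyond the scatter)). Nothing given here explains these numbers.

From the compounds shown here alone, it remains open whether a primary amine, a carboxylic acid or a longer ether chain on this ring carbon would give a number outside the scatter of compound 3 and compound 4.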